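Swapping the amide substituent in an azetidine oxadiazole series

The compounds below may be only part of what the source reports. "The series", "measured", "known", "first", "only" and "open" are said of these compounds alone.

Measured so far:
compound 1, `O=C(c1ccc(F)c(F)c1)N1CC(c2nc(-c3cccc(F)c3)no2)C1`, > 10000 nM
compound 2, `O=C(C1CCC2(CCC2)CC1)N1CC(c2nc(-c3cccc(Cl)c3)no2)C1`, > 10000 nM

Both measured compounds were tested in an assay on HEK293 cells for negative allosteric modulation of metabotropic glutamate receptor 5 (Homo sapiens), read by FLIPR; a higher number here means a weaker inhibitor, a lower number a stronger inhibitor. For compound 1 the result is a limit of the assay and not a number, namely > 10000 nM. For compound 2 the result is likewise only a limit, > 10000 nM. Among the measured compounds shown here, compound 2 therefore stands at the edge of what the assay can report, as summarised by the limit of > 10000 nM in this assay, at which 2 of the 2 values shown sit, and no step between two measured numbers is available here.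

The next compound, compound 3, `CC1CCN(C(=O)N2CC(c3nc(-c4cccc(Cl)c4)no3)C2)C1`, differs from compound 2 at the carbonyl carbon: a group of 6 heavy atoms (5 carbon, 1 nitrogen; one five-membered non-aromatic ring with 1 hetero atom) in place of a group of 9 heavy atoms (9 carbon; one four-membered non-aromatic ring of carbon only, one six-membered non-aromatic ring of carbon only), on a carbonyl carbon

With both known values sitting at the limit, the step from compound 2 to compound 3 cannot be anchored on a measured difference. The author expects the step of a number no higher from compound 2 to compound 3 (the limit leaves the size open) to be no larger than the scatter in either direction, and most probably another limit. For compound 3 the estimated value in this assay is 10000 nM, within an expected range from 3000 nM to 30000 nM.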

Compound 3, half-maximal inhibitory concentration: > 10000 nM
Compound 3: only a limit was reported; the forecaster's own chance of this, stated with the estimate: 70%; the middle value sits exactly at the limit.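

Compound 3 gives > 10000 nM, which is a limit of the assay and not a number. Among the compounds shown here, compound 2 is also reported only as a limit, so no step from compound 2 to compound 3 can be read. The compounds shown leave open how strongly any of them inhibits, and whether exchanging the amide substituent changes that.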